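The source may report more compounds than this note shows. Statements on the series, on what has been measured and on what is new or still open speak of the compounds shown alone.

In a functional assay on MCF7 cells (Homo sapiens) for cytotoxicity, read by CellTiter-Glo, with a stated time of 5 days (a higher number here means a weaker inhibitor, a lower number a stronger inhibitor), compound 1 `CC/C(=C(/c1ccc(/C=C/C(=O)O)cc1)c1ccc2[nH]ncc2c1)c1ccccc1C#N` gives 12 nM with a 2-cyanophenyl group, and compound 2 `CC/C(=C(/c1ccc(/C=C/C(=O)O)cc1)c1ccc2[nH]ncc2c1)c1ccc(C#N)cc1` gives 47 nM with a 4-cyanophenyl group. Compound 2 therefore holds the higher of the two numbers and is the weaker inhibitor of this pair. Compound 3 `CC/C(=C(/c1ccc(/C=C/C(=O)O)cc1)c1ccc2[nH]ncc2c1)c1ccccc1OC` differs from compound 2 as follows (2-methoxyphenyl in place of 4-cyanophenyl on a double-bonded chain carbon bound to a double-bonded chain carbon and a saturated chain carbon): 2-methoxyphenyl in place of 4-cyanophenyl on a double-bonded chain carbon bound to a double-bonded chain carbon and a saturated chain carbon. Within the data shown here, the only measured step bearing on this is a 3.9-fold higher number from compound 1 to compound 2 (0.59 log units; beyond the scatter) on going from 2-cyanophenyl to 4-cyanophenyl, so with a group named with a 2 back in compound 3, a partial return toward a lower number is expected in this assay here. Among the measured compounds shown here, no measured compound yet carries a methoxy group, so this expectation is loose. The expected step is a 2.1-fold lower number from compound 2 to compound 3 (0.33 log units; beyond the scatter) and it remains an estimate. The estimated value for compound 3 is 22 nM with an expected range from 6 nM to 75 nM for repeated measurements.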

Compound 3, half-maximal inhibitory concentration: 25 nM
Compound 3: the middle estimate sits 1.1-fold (0.06 log units) below what was measured; the range from low to high includes it.
By their numbers in this assay, from the lowest: compound 1; then compounds 3 and 2 (each within the scatter of the next).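

Placing methoxy in place of cyano on an aromatic carbon gives a 2.1-fold higher number from compound 1 to compound 3 (0.32 log units; beyond the scatter) in this assay, so the group itself counts here as well as its place on the ring. Going from 4-cyanophenyl to 2-methoxyphenyl gives a 1.9-fold lower number from compound 2 to compound 3 (0.27 log units; within the scatter) and leaves the two compounds indistinguishable, which makes compound 1 the strongest inhibitor of the three, with its steps to both others beyond the scatter. Nothing available explains why these groups compare as they do.

The compounds shown do not tell whether a methoxy group would keep this value if it were carried as the cyano group is in compound 2. They also leave open how a chlorine atom or a methyl group would compare with cyano and methoxy on that aromatic carbon.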